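The source may report more compounds than this note shows. Statements on the series, on what has been measured and on what is new or still open speak of the compounds shown alone.

In a functional assay on A2780 cells (Homo sapiens) for cytotoxicity, read by MTT assay, with a stated time of 72 h (on this read-out lower numbers stand for stronger inhibition and higher numbers for weaker inhibition), compound 1 (`Cc1cc(C)cc(C(=O)N(CCCCCC(=O)Nc2ccccc2N)CC(=O)NC2CCCCC2)c1`) gives 42000 nM, while compound 2 (`CN(C)c1ccc(C(=O)N(CC(=O)NCc2ccccc2)Cc2ccc(C(=O)Nc3ccccc3N)cc2)cc1`) gives 2400 nM. Compound 2 thus holds the lower of the two numbers, and the gap between them lies beyond the usual scatter. Compound 3 (`Cc1cc(C)cc(C(=O)N(CC(=O)NCc2ccccc2)Cc2ccc(C(=O)Nc3ccccc3N)cc2)c1`) departs from compound 2 by a single change, on a carbonyl carbon whose other neighbour is an amide-type nitrogen: 3,5-dimethylphenyl in place of 4-(dimethylamino)phenyl on a carbonyl carbon. For the measured compounds named here, compound 1 also carries 3,5-dimethylphenyl, but it differs from compound 2 elsewhere too, so no measured pair isolates this exchange. The expected result in this assay is therefore no clear shift, with only a slight lean towards a higher number. The estimated change is a 1.3-fold higher number from compound 2 to compound 3 (0.10 log units; within the scatter), which is expected to stay within the scatter. For compound 3 the estimated value is 3000 nM, with an expected range from 1000 nM to 9000 nM.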

Compound 3, half-maximal inhibitory concentration: 2800 nM
Beside the measured number, compound 3's estimate is 1.1-fold (0.03 log units) above it; the range from low to high includes it.
By their numbers in this assay, from the lowest: compounds 2 and 3 (each within the scatter of the next); then compound 1.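

With compound 3 the account gains its first pair that differs in one place: on a carbonyl carbon whose other neighbour is an amide-type nitrogen, 3,5-dimethylphenyl takes the place of 4-(dimethylamino)phenyl, and a 1.2-fold higher number from compound 2 to compound 3 (0.07 log units; within the scatter) is what this assay records for this exchange. On this shared core, then, the exchange removes the nitrogen and the hydrogen-bond acceptor counted for the leaving group and still leaves the two compounds within the scatter of each other. No accompanying measurement bears on why the two groups read alike.

As far as these compounds go, whether a carboxylic acid, a primary amine or a morpholine on that carbonyl carbon would read the same stays open. Compound 1 also carries 3,5-dimethylphenyl but differs from compound 3 elsewhere, so the contribution of its other parts cannot be read from these compounds.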